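The compounds below may be only part of what the source reports. "The series", "measured", "known", "first", "only" and "open" are said of these compounds alone.

In a functional assay on HL-60 cells (Homo sapiens) for antiproliferative activity, read by MTT assay, with a stated time of 72 h (on this read-out lower numbers stand for stronger inhibition and higher numbers for weaker inhibition), compound 1 `COc1ccc(-c2c(C(=O)c3cc(OC)c(OC)c(OC)c3)sc3ccccc23)cc1` gives 1600 nM and compound 2 `COc1cc(C(=O)c2sc3ccccc3c2Nc2ccc(C)cc2)cc(OC)c1OC` gives 4600 nM, the higher of the two numbers and so the weaker result of this pair. Compound 3 `CCOc1ccc(Nc2c(C(=O)c3cc(OC)c(OC)c(OC)c3)sc3ccccc23)cc1` has ethoxy in place of methyl on an aromatic carbon, para to a large group: ethoxy in place of methyl on an aromatic carbon. Among the compounds with values here, only one measured step bears on this change, a 2.9-fold higher number from compound 1 to compound 2 (0.46 log units; beyond the scatter), and it is modest. Within the data shown here, that step replaced 4-methoxyphenyl with (4-methylphenyl)amino, so it is only a loose guide, and no measured compound carries ethoxy. Compound 3 keeps the amino link of compound 2, but its 4-ethoxyphenyl holds an oxygen, as the 4-methoxyphenyl of compound 1 does. A small move towards compound 1 therefore seems likely, and the expected step is a 1.5-fold lower number from compound 2 to compound 3 (0.19 log units; within the scatter). For compound 3 the estimated value is 3000 nM, with an expected range from 900 nM to 10000 nM.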

Compound 3, half-maximal inhibitory concentration: 500 nM
Beside the measured number, compound 3's estimate is 6.0-fold (0.78 log units) above it; measured number outside the range, below it.
By their numbers in this assay, from the lowest: compound 3; then compound 1; then compound 2.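

In this assay, the group at the outer end of the amino link clearly counts: ethoxy in place of methyl, on an aromatic carbon para to a large group, gives a 9.2-fold lower number from compound 2 to compound 3 (0.96 log units; beyond the scatter). Putting (4-ethoxyphenyl)amino in place of 4-methoxyphenyl gives a 3.2-fold lower number from compound 1 to compound 3 (0.51 log units; beyond the scatter), so the loss seen in a 2.9-fold higher number from compound 1 to compound 2 (0.46 log units; beyond the scatter) does not hold for every amino-linked compound, and the ethoxy compound now has the lowest number of the three. Nothing available here explains why this change has so large an effect.

The compounds shown cannot separate the part played by the oxygen from that of the ethyl group within ethoxy, which a methoxy group on the same amino-linked ring would help to do. Going by these compounds, how a longer chain such as propoxy, or an amine, would behave at this place also remains open.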